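This account rests on a few compounds, and the source may have more. Where it says the series, first, only, none or still open, it means among the compounds named here.

Measured so far:
- compound 1 `O=C(c1ccccc1)N1CCC(C(=O)N2N=CCC2c2ccccc2)CC1`: 0.0833 h
- compound 2 `N#Cc1cc(N2CCC(C(=O)N3N=CC[C@H]3c3cc(F)cc(F)c3)CC2)ncn1`: 1.15 h
- compound 3 `O=C(C1CCOCC1)N1N=CCC1c1ccccc1`: > 1.5 h

In an ADME assay on microsomes (Rattus norvegicus) for metabolic stability (on this read-out lower numbers stand for a shorter-lived compound and higher numbers for a longer-lived compound), compound 1 gives 0.0833 h, the lower of the two actual numbers, and compound 2 gives 1.15 h, a gap well beyond the usual scatter. Compound 3 is reported only as a limit, > 1.5 h.

Compound 4 `O=C(c1cc[nH]n1)N1CCC(C(=O)N2N=CCC2c2ccccc2)CC1` keeps the rest of compound 1 but carries 1H-pyrazol-3-yl in place of phenyl on a carbonyl carbon. Among the measured compounds shown here, no measured pair of compounds shows this exchange on its own, so any forecast is loose. A rise is more likely than a fall because compound 1 stands at 0.0833 h, the bottom of the numbers seen in this assay. The expected change is modest, only a little past the scatter: a 3.0-fold higher number from compound 1 to compound 4 (0.48 log units; beyond the scatter). For compound 4 the estimated half-life is 0.25 h, with an expected range of 0.1 h to 0.8 h.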

Compound 4, half-life: 0.317 h
Compound 4: middle estimate off by 1.3-fold (0.10 log units), on the low side; the range from low to high includes it.
By their numbers in this assay, from the lowest: compound 1; then compound 4; then compound 2. At a limit, above all of these: compound 3.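

In this assay, among the compounds shown here, putting 1H-pyrazol-3-yl in place of phenyl on a carbonyl carbon gives a 3.8-fold higher number from compound 1 to compound 4 (0.58 log units; beyond the scatter), the first change in a single place seen here. This shows that the position is not silent: a ring of carbon only gave way to a five-membered ring with two nitrogens, and the half-life moved by a modest step. Only compound 3 is reported at a limit of the assay rather than a number, so this step between two actual numbers is not cut off: the limit of > 1.5 h in this assay, at which 1 of the 4 values shown sits.

One pair cannot tell whether the ring nitrogens, the hydrogen-bond donor or the smaller ring accounts for the step. A pyridyl ring or a pyrazole with a methyl group on its ring nitrogen at this place would help to separate these differences.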